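From acetamido to methanesulfonamido on a serotonin receptor ligand

A few compounds are considered here, and "the series" means these few. Any claim that something is new, unique, unknown or untested is made for them only; others in the source may bear on it.

Two compounds share a core and differ only in one group on an aromatic ring. Compound 1 `CN(CCCN1CCN(c2ccccc2)CC1)c1cccc(O)c1` carries a hydroxy group there and, in an assay on HEK293 cells for displacement of a labelled ligand from 5-hydroxytryptamine receptor 7 (Homo sapiens), read by scintillation counting, with a stated time of 30 min (on this read-out higher numbers stand for weaker inhibition and lower numbers for stronger inhibition), compound 1 gives 20 nM. Compound 2 `CC(=O)Nc1cccc(N(C)CCCN2CCN(c3ccccc3)CC2)c1` carries an acetamido group instead and gives 161 nM, the higher of the two numbers, so compound 2 is the weaker binder; the step of an 8.1-fold higher number from compound 1 to compound 2 (0.91 log units; beyond the scatter) is beyond the scatter.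

Compound 3 `CN(CCCN1CCN(c2ccccc2)CC1)c1cccc(NS(C)(=O)=O)c1` is the next variation: methylsulfonyl in place of acetyl on a nitrogen on an aromatic ring, so the acetamido becomes a methanesulfonamido. Within the data shown here, no measured step addresses this exchange. Among the measured compounds shown here, the one step known, from hydroxy to acetamido, only shows that adding a larger group on this position costs affinity, and says nothing about exchanging one capping group for another of similar size. Compound 3 is therefore expected to stay close to compound 2, with a step of a 1.1-fold higher number from compound 2 to compound 3 (0.05 log units; within the scatter). The estimated value for compound 3 in this assay is 180 nM, with a range from 60 nM to 550 nM.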

Compound 3, inhibition constant: 39.6 nM
The estimate for compound 3 lay 4.5-fold (0.66 log units) above the measured number, and the stated range ends above it.
By their numbers in this assay, from the lowest: compounds 1 and 3 (each within the scatter of the next); then compound 2.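

The capping group on this nitrogen matters in its own right: with the rest of the molecule unchanged, methylsulfonyl in place of acetyl gives a 4.1-fold lower number from compound 2 to compound 3 (0.61 log units; beyond the scatter) in this assay, so compound 3 binds more strongly than compound 2. The earlier step from hydroxy to acetamido could have suggested that a larger group here simply costs affinity, but compound 3 goes against that reading, as methylsulfonyl has 4 heavy atoms against 3 in acetyl, and a 2.0-fold higher number from compound 1 to compound 3 (0.30 log units; within the scatter) leaves the methanesulfonamido and hydroxy compounds indistinguishable in this measurement. No supporting data are available to explain why the exchange of capping groups changes binding.

As far as these compounds go, with only these three compounds, it remains open whether the gain belongs to methylsulfonyl alone or extends to other capping groups on this nitrogen, such as ethylsulfonyl or trifluoroacetyl. From the compounds shown here alone, it is also open how an unsubstituted amine or a carboxylic acid in place of the hydroxy would compare, and whether the match between compound 1 and compound 3 would survive a longer chain in the shared core.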